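This account rests on a few compounds, and the source may have more. Where it says the series, first, only, none or still open, it means among the compounds named here.

Compound 1 `CCCCNc1nc(N)nc2ccn(CC(=O)NC)c12`: > 25 uM
Compound 2 `CCCCNc1nc(N)nc2ccn(Cc3cn4ccccc4n3)c12`: > 25 uM

Compound 1 stands at the edge of what an assay on HEK293 cells for agonist activity at Toll-like receptor 8 (Homo sapiens), read by a luciferase reporter, with a stated time of 6 h (a lower number here means that less compound is needed, a higher number that more compound is needed for the effect), can report: in this assay compound 1 gives > 25 uM, which is a limit of the assay and not a number. Compound 2 likewise gives only a limit in this assay, > 25 uM. So the whole picture so far is the limit of > 25 uM in this assay, at which 2 of the 2 values shown sit, with no measured step between compounds to lean on.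

Compound 3 `CCCCNc1nc(N)nc2ccn(Cc3ccccn3)c12` takes the path from compound 1: pyridin-2-yl in place of methylcarbamoyl on a saturated chain carbon bound to an aromatic nitrogen. Compound 2 already carries an aromatic group at that same place and reaches no number either. On that basis the step from compound 1 to compound 3 is expected to be a step that the limit leaves unreadable from compound 1 to compound 3, that is, none beyond the scatter, and compound 3 is most likely to return a limit as well. Compound 3 is estimated to give 30 uM in this assay, within 10 uM to 100 uM.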

Compound 3, minimum effective concentration: > 25 uM
Compound 3: a limit, no number (the forecaster's own chance of this, stated with the estimate: 70%); the middle value does not contradict the limit.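

Compound 1 and compound 3 each return only a limit of the assay and not a number, so no step can be read between them. The compounds shown leave open whether any group on a saturated chain carbon bound to an aromatic nitrogen gives a number in this assay: the limit of > 25 uM in this assay, at which 3 of the 3 values shown sit.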